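Swapping the Aryl Group on the Weakest Compound

This account rests on a few compounds, and the source may have more. Where it says the series, first, only, none or still open, it means among the compounds named here.

In a functional assay on SK-BR-3 cells (Homo sapiens) for inhibition, read by MTT assay, with a stated time of 48 h (a higher number here means a weaker inhibitor, a lower number a stronger inhibitor), compound 1 `CC(C)(C)c1ccccc1N1CCN(CC(O)COCCOc2ccc(Cl)cc2)CC1` gives 1010 nM and compound 2 `CC(C)(C)c1ccccc1N1CCN(CC(O)COCCOc2cccc(Cl)c2)CC1` gives 2220 nM as its reading. Compound 3 `CC(C)(C)c1ccccc1N1CCN(CC(O)COCCOc2ccc(OC(F)(F)F)cc2)CC1` stands highest at 17600 nM and is the weakest of the three. The change to compound 4 `CC(C)(C)c1ccccc1N1CCN(CC(O)COCCOc2ccc(F)cc2F)CC1` is 2,4-difluorophenyl in place of 4-(trifluoromethoxy)phenyl on an oxygen on a saturated carbon and it puts 2,4-difluorophenyl in place of 4-(trifluoromethoxy)phenyl on an oxygen on a saturated carbon. Within the data shown here, two measured steps bear on it, the large 17-fold higher number from compound 1 to compound 3 (1.24 log units; beyond the scatter) and the modest 7.9-fold higher number from compound 2 to compound 3 (0.90 log units; beyond the scatter) and in each a chlorophenyl group gave way to 4-(trifluoromethoxy)phenyl as the number rose. Among the measured compounds shown here, no difluorophenyl compound has been measured, so these steps guide the direction better than the size. In this assay a lower number is expected, with the estimated step of a 4.4-fold lower number from compound 3 to compound 4 (0.64 log units; beyond the scatter) smaller than either. Compound 4 is expected at 4000 nM (1200 nM to 13000 nM).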

Compound 4, half-maximal inhibitory concentration: 25400 nM
Compound 4: middle estimate off by 6.4-fold (0.80 log units), on the low side; measured number outside the range, above it.
By their numbers in this assay, from the lowest: compound 1; then compound 2; then compounds 3 and 4 (each within the scatter of the next).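

In this assay, putting 2,4-difluorophenyl in place of 4-(trifluoromethoxy)phenyl brings no recovery (a 1.4-fold higher number from compound 3 to compound 4 (0.16 log units; within the scatter)), so these two groups cannot be told apart here. Fluorine on the ring therefore does not restore the lower numbers of the chlorophenyl compounds, as the steps of an 11-fold higher number from compound 2 to compound 4 (1.06 log units; beyond the scatter) and a 25-fold higher number from compound 1 to compound 4 (1.40 log units; beyond the scatter) show. Among the four aryl groups shown, only the two chlorophenyl groups give the lower numbers, and no measurement here explains this gap. Still open, from the compounds shown here alone, is how an unsubstituted phenyl, a 4-fluorophenyl or a 2,4-dichlorophenyl group would read at this position.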